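The source may report more compounds than this note shows. Statements on the series, on what has been measured and on what is new or still open speak of the compounds shown alone.

Measured compounds in an assay on isolated protein for inhibition of Apoptosis regulator Bcl-2 (Homo sapiens), read by fluorescence polarization, with stated times of 5 min and 10 min; a higher number here means a weaker inhibitor, a lower number a stronger inhibitor:
- compound 1 `CC(C)=CCCC1=CC[C@H](C(=O)Nc2ccc(O)cc2)[C@@H](c2ccccc2)C1` gives > 23000 nM, a limit of the assay and not a number.
- compound 2 `COc1ccc(NC(=O)[C@H]2CC=C(CCC=C(C)C)C[C@@H]2c2ccccc2)cc1` gives > 23000 nM, also a limit.
- compound 3 `CC(C)=CCCC1=CC[C@H](C(=O)N(C)O)[C@@H](c2ccccc2)C1` gives 2100 nM.

Among the measured compounds shown here, compound 3 holds the only actual number in this assay; the two other values shown are limits, which is the situation described by the limit of > 23000 nM in this assay, at which 2 of the 3 values shown sit. The steps of an at least 10-fold lower number from compound 1 to compound 3 (1.03 log units; beyond the scatter) and an at least 10-fold lower number from compound 2 to compound 3 (1.03 log units; beyond the scatter) are both large, but each runs from a limit, so only their minimum size is known. The step that the two limits leave unreadable from compound 1 to compound 2 cannot be read at all, since both ends sit at the limit.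

Compound 4 `CON(C)C(=O)[C@H]1CC=C(CCC=C(C)C)C[C@@H]1c1ccccc1` differs from compound 3 as follows: methyl in place of hydrogen on an oxygen. For the measured compounds named here, the one measured step of the same kind, methyl in place of hydrogen on an oxygen, is the one from compound 1 to compound 2, and it is unreadable; it also sits on an aromatic ring rather than on an oxygen whose other neighbour is an amide-type nitrogen. Going by the values given here, no measured step therefore reads the size of this change, and the expectation is a step of no clear direction, at most modest and possibly within the scatter, expressed as a 1.9-fold higher number from compound 3 to compound 4 (0.28 log units; within the scatter).

Compound 4 is estimated at 4000 nM in this assay, with a range from 1200 nM to 15000 nM.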

Compound 4, inhibition constant: 300 nM
Beside the measured number, compound 4's estimate is 13-fold (1.12 log units) above it, and the stated range ends above it.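

In this assay, the position is the oxygen of the hydroxy(methyl)amino group, and methoxy(methyl)amino in its place gives a 7.0-fold lower number from compound 3 to compound 4 (0.85 log units; beyond the scatter), so the hydrogen on this oxygen is not needed for a measured value and methyl is accepted there with a gain beyond the scatter. Among the compounds shown here, this is the first readable reading of methyl in place of hydrogen on an oxygen, since the earlier step of that kind, on an aromatic ring, cannot be read. Compound 4 also widens the gap to the two aryl amides, with an at least 76-fold lower number from compound 2 to compound 4 (1.88 log units; beyond the scatter) and an at least 76-fold lower number from compound 1 to compound 4 (1.88 log units; beyond the scatter), and only the minimum size of these two steps is known because each starts from a limit: the limit of > 23000 nM in this assay, at which 2 of the 4 values shown sit.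

As far as these compounds go, whether the gain continues with an ethyl or a benzyl group on this oxygen, or stops at methyl, remains open. Also open, from the compounds shown here alone, is what an ethyl group or a hydrogen in place of the methyl on the amide-type nitrogen would give, and how a carboxylic acid in place of the whole methoxy(methyl)carbamoyl group would compare on the shared core.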